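The compounds below may be only part of what the source reports. "The series", "measured", "known", "first", "only" and "open" are said of these compounds alone.

Compound 1 `CCOC(=O)c1c(C(F)(F)F)[n+]([O-])c2ccc(OC)cc2[n+]1[O-]` carries a methoxy group on the six-membered aromatic ring of carbon only within its shared core. Among the compounds with values here, in an ADME assay on J774 cells (Mus musculus) for cytotoxicity, read by MTT assay, with a stated time of 48 h (a lower number here means a stronger inhibitor, a higher number a weaker inhibitor), compound 1 gives 6000 nM, the highest of the three numbers so far measured. Compound 2 `CCOC(=O)c1c(C(F)(F)F)[n+]([O-])c2ccc(F)cc2[n+]1[O-]` gives 500 nM in this assay, and compound 3 `COC(=O)c1c(C(F)(F)F)[n+]([O-])c2cc(Cl)c(Cl)cc2[n+]1[O-]` gives 500 nM. Compound 4 `CCOC(=O)c1c(C(F)(F)F)[n+]([O-])c2ccc(C(F)(F)F)cc2[n+]1[O-]` has not yet been measured in this assay. It differs from compound 1 in one place: trifluoromethyl in place of methoxy on an aromatic carbon. Within the data shown here, the only measured step that alters the same aromatic carbon of compound 1 is the exchange of methoxy for fluoro, which gave a 12-fold lower number from compound 1 to compound 2 (1.08 log units; beyond the scatter). Among the measured compounds shown here, compound 3 differs from compound 1 in more than one place, carrying two chlorines and a methyl ester in place of an ethyl ester, so no single step to it is known; its value shows only that a second analogue with a different substituent on that ring also lies well below compound 1. With one directly comparable step pointing to a lower number, the expected step is an 8.6-fold lower number from compound 1 to compound 4 (0.93 log units; beyond the scatter), toward a lower number, though its size is uncertain. The estimate for compound 4 in this assay is 700 nM, with a range from 250 nM to 2500 nM.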

Compound 4, half-maximal inhibitory concentration: 4200 nM
Estimate against measurement, compound 4: 6.0-fold (0.78 log units) below; the whole stated range lies below it.
By their numbers in this assay, from the lowest: compounds 2 and 3 (each within the scatter of the next); then compounds 4 and 1 (each within the scatter of the next).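

In this assay, the change at this aromatic carbon does not act in one direction once methoxy leaves: a 1.4-fold lower number from compound 1 to compound 4 (0.15 log units; within the scatter) stays within the scatter, so trifluoromethyl and methoxy cannot be told apart here, whereas an 8.4-fold higher number from compound 2 to compound 4 (0.92 log units; beyond the scatter) lies beyond it. Taken with a 12-fold lower number from compound 1 to compound 2 (1.08 log units; beyond the scatter), this shows that losing methoxy is not enough by itself to give a low number, and that among the three groups compared at this carbon only fluoro does so, with compounds 1 and 4 sitting together well above compound 2. The data shown offer no measurement that explains why fluoro stands apart from the other two groups.

The compounds shown do not tell whether an amine, a nitrile or a carboxylic acid at this aromatic carbon would fall with fluoro or with methoxy and trifluoromethyl, so three groups are all that define this position. They also leave open whether the gap between fluoro and trifluoromethyl holds with a methyl ester in place of the ethyl ester, since compound 3 differs from each of these compounds in more than one place.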